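One Swap, Seen Once, Tried Again

The source may report more compounds than this note shows. Statements on the series, on what has been measured and on what is new or still open speak of the compounds shown alone.

In a functional assay on HL-60 cells (Homo sapiens) for cytotoxicity, read by MTT assay, with a stated time of 72 h (on this read-out higher numbers stand for weaker inhibition and lower numbers for stronger inhibition), the three measured compounds gave these values:
Compound 1, `O=S(=O)(c1ccccc1)c1nc2ccccc2nc1Nc1ccc(Cl)cc1`: 1920 nM
Compound 2, `O=S(=O)(c1ccccc1)c1nc2ccccc2nc1Nc1ccc(C(F)(F)F)cc1`: 300 nM
Compound 3, `COc1ccc(S(=O)(=O)c2nc3ccccc3nc2Nc2ccc(Cl)cc2)cc1`: 19600 nM

Compound 1 and compound 2 differ only by trifluoromethyl in place of chloro on an aromatic carbon, and that change gave a 6.4-fold lower number from compound 1 to compound 2 (0.81 log units; beyond the scatter). Compound 3 differs from compound 1 by methoxy in place of hydrogen on an aromatic carbon, a change that gave a 10-fold higher number from compound 1 to compound 3 (1.01 log units; beyond the scatter) and left compound 3 with the highest number of the three. Within the data shown here, compound 4, `COc1ccc(S(=O)(=O)c2nc3ccccc3nc2Nc2ccc(C(F)(F)F)cc2)cc1`, has not been measured; it differs from compound 3 by trifluoromethyl in place of chloro on an aromatic carbon, the same change at the same place as the one from compound 1 to compound 2. In this assay compound 4 is expected to show a 5.6-fold lower number from compound 3 to compound 4 (0.75 log units; beyond the scatter), a step of about the same size as the earlier one. Among the measured compounds shown here, that expectation rests on the single earlier instance, a 6.4-fold lower number from compound 1 to compound 2 (0.81 log units; beyond the scatter), so it carries real uncertainty. Compound 4 is therefore estimated at 3500 nM, with a likely range from 1000 nM to 12000 nM.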

Compound 4, half-maximal inhibitory concentration: 220 nM
Beside the measured number, compound 4's estimate is 16-fold (1.20 log units) above it; the whole stated range lies above it.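

Trifluoromethyl in place of chloro gave an 89-fold lower number from compound 3 to compound 4 (1.95 log units; beyond the scatter) in this assay, so the direction held on the methoxy-bearing core, but the size of the step did not carry over: the same change on two cores in this assay, a 6.4-fold lower number (0.81 log units; beyond the scatter) from compound 1 to compound 2 and an 89-fold lower number (1.95 log units; beyond the scatter) from compound 3 to compound 4, 14-fold (1.14 log units) apart, beyond the scatter of two such steps

With trifluoromethyl present, methoxy in place of hydrogen gave only a 1.4-fold lower number from compound 2 to compound 4 (0.13 log units; within the scatter), which is a very different result from its effect with chloro present: the same change on two cores in this assay, a 10-fold higher number (1.01 log units; beyond the scatter) from compound 1 to compound 3 and a 1.4-fold lower number (0.13 log units; within the scatter) from compound 2 to compound 4, 14-fold (1.14 log units) apart, beyond the scatter of two such steps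

Across these four compounds, the effect of each change therefore depends on the other group, but this does not show why, and two pairs give no rule for other cores.

Going by these compounds, it remains open whether a nitrile or an amine in place of trifluoromethyl, or a methyl in place of methoxy, would show the same dependence.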